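Cyclopentylamino to isobutylamino: working notes on the series

A few compounds are considered here, and "the series" means these few. Any claim that something is new, unique, unknown or untested is made for them only; others in the source may bear on it.

Compound 1 `C=CCOc1nc(N)nc2c1ncn2/C=C1/CC1(CO)CO`: > 20000 nM (a limit)
Compound 2 `CCCCCCCCOc1nc(N)nc2c1ncn2/C=C1/CC1(CO)CO`: > 20000 nM (a limit)
Compound 3 `Nc1nc(NC2CCCC2)c2ncn(/C=C3/CC3(CO)CO)c2n1`: > 20000 nM (a limit)

All three compounds were tested in an ADME assay on CCRF-HSB-2 cells (Homo sapiens) for cytotoxicity, with a stated time of 7 days; a lower number here means that less compound is tolerated, a higher number that more compound is tolerated. Compound 3 has no numerical value, only the limit > 20000 nM. The next structure is compound 4 `CC(C)CNc1nc(N)nc2c1ncn2/C=C1/CC1(CO)CO`. The change is isobutyl in place of cyclopentyl on a nitrogen on an aromatic ring.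

The measured steps that bear on this change are a step that the two limits leave unreadable from compound 1 to compound 3 and a step that the two limits leave unreadable from compound 2 to compound 3, since both end at the cyclopentylamino compound. The remaining one is a step that the two limits leave unreadable from compound 1 to compound 2. None of them has a readable size, so none gives a measured effect for the group on this position. Going by the values given here, the whole series so far amounts to the limit of > 20000 nM in this assay, at which 3 of the 3 values shown sit.

The expectation therefore rests on compound 3 and its limit > 20000 nM. In this assay the estimated change is expected to be a step that the limit leaves unreadable from compound 3 to compound 4, with no change beyond the scatter, and another limit is the likeliest report. The estimate for compound 4 is 25000 nM, with an expected range of 15000 nM to 50000 nM.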

Compound 4, half-maximal cytotoxic concentration: > 20000 nM
Compound 4 gave a limit, no number (the forecaster's own chance of this, stated with the estimate: 85%); the middle value lies beyond the limit too.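

In this assay compound 4 gives > 20000 nM, a limit, and its steps from compound 1, compound 2 and compound 3 cannot be read. The series stands at a single limit: the limit of > 20000 nM in this assay, at which 4 of the 4 values shown sit.

The compounds shown leave open whether the groups on the shared core differ at all in this read-out, as none of them has a numerical value.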